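The compounds below may be only part of what the source reports. "The series", "measured", "known", "first", "only" and "open" are said of these compounds alone.

Compound 1 `Cc1c(OC[C@H](C)Oc2ccc(F)c(C(=O)O)c2)ccc(C(=O)CC(C)(C)C)c1O` — 142 nM
Compound 2 `Cc1c(O[C@@H](C)COc2ccc(F)c(C(=O)O)c2)ccc(C(=O)CC(C)(C)C)c1O` — 257 nM
Compound 3 `Cc1cc(C(=O)O)ccc1OC[C@H](C)COc1ccc(C(=O)CC(C)(C)C)c(O)c1C` — 446 nM

Of the compounds shown here, three have been measured in an assay for positive allosteric modulation of metabotropic glutamate receptor 2 (Rattus norvegicus); a higher number here means that more compound is needed for the effect, a lower number that less compound is needed. Compound 3 gives the highest of the three numbers, 446 nM. Its nearest neighbour is compound 2 with 257 nM; that gap lies within the usual scatter of this assay, so the two cannot be told apart on these numbers alone. Compound 1 with 142 nM stands furthest away, and here the gap is larger than the scatter, so compound 1 needs less compound for the effect than compound 3.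

Compound 4 `COc1ccccc1OC[C@H](C)COc1ccc(C(=O)CC(C)(C)C)c(O)c1C` has not yet been measured. It differs from compound 3 in one place: 2-methoxyphenyl in place of 4-carboxy-2-methylphenyl on an oxygen on a saturated carbon. The group that leaves carries a carboxylic acid and a methyl; the group that enters carries a methoxy instead. Going by the values given here, no pair among the measured compounds shows the effect of removing the carboxylic acid, so the size of the step can only be guessed. The expectation is that compound 4 will need more compound than compound 3, a step of a 2.0-fold higher number from compound 3 to compound 4 (0.30 log units; within the scatter) in this assay. Compound 4 is therefore expected to give about 900 nM, with a plausible range from 250 nM to 3500 nM.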

Compound 4, half-maximal effective concentration: "not active" (no number reported)
Compound 4 has no reported number here, so the estimate cannot be set against anything.
By their numbers in this assay, from the lowest: compounds 1, 2 and 3 (each within the scatter of the next, the first and the last beyond it).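

Going by these compounds alone, compound 4 is reported as not active in this assay, without a number, so no step from compound 3 to compound 4 can be read. The compounds shown leave open whether the carboxylic acid, the methyl or the methoxy matters for this result. No other data at hand bear on this outcome.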